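Trading a substituted benzyl for a plain methylbenzyl

This account rests on a few compounds, and the source may have more. Where it says the series, first, only, none or still open, it means among the compounds named here.

Measured compounds:
compound 1, `COc1ccc(CN(C(=O)CSc2nc3ccccc3s2)c2cc(OC)c(OC)c(OC)c2)cc1F`: 20100 nM
compound 2, `COc1ccc(CN(C(=O)CSc2nc3ccccc3s2)c2cc(OC)c(OC)c(OC)c2)cc1C`: 34300 nM
compound 3, `COc1ccc(CN(C(=O)CSc2nc3cc(Br)ccc3s2)c2cc(OC)c(OC)c(OC)c2)cc1O`: 8210 nM

In a functional assay on PC-3 cells (Homo sapiens) for antiproliferative activity, read by MTT assay, with a stated time of 48 h (on this read-out higher numbers stand for weaker inhibition and lower numbers for stronger inhibition), compound 1 gives 20100 nM, which puts it second highest among the three numbers. Its nearest neighbour is compound 2, and the step of a 1.7-fold higher number from compound 1 to compound 2 (0.23 log units; within the scatter) stays within the scatter. Going by the values given here, compound 3, which carries a bromo on the shared core and a hydroxy in place of the fluoro, is the furthest away, with a number beyond the scatter below that of compound 1; no single-point step links it to compound 1, so only the two values can be compared.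

Compound 4, `COc1cc(N(Cc2ccc(C)cc2)C(=O)CSc2nc3ccccc3s2)cc(OC)c1OC`, differs from compound 1 as follows: 4-methylphenyl in place of 3-fluoro-4-methoxyphenyl on a saturated chain carbon bound to an amide-type nitrogen

Among the compounds with values here, the only single-point step measured, from compound 1 to compound 2, exchanges fluoro for methyl on an aromatic carbon and produces no change beyond the scatter. Within the data shown here, no measured step removes the methoxy from the benzyl group, so that part of the change is uncovered by the data. The account therefore expects compound 4 to stay close to compound 1, with the step of a 1.2-fold higher number from compound 1 to compound 4 (0.09 log units; within the scatter) expected to lie within the scatter. For compound 4 the estimate in this assay is 25000 nM, expected to fall between 8000 nM and 70000 nM.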

Compound 4, half-maximal inhibitory concentration: > 80000 nM
Compound 4: a limit, no number (the forecaster's own chance of this, stated with the estimate: 10%); middle value at least 3.2-fold (0.50 log units) from the limit.
By their numbers in this assay, from the lowest: compound 3; then compounds 1 and 2 (each within the scatter of the next). At a limit, above all of these: compound 4.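

In this assay compound 4 stands at a limit of the assay and not at a number: the limit of > 80000 nM in this assay, at which 1 of the 4 values shown sits. Replacing the substituted benzyl gives an at least 3.9-fold higher number from compound 1 to compound 4 (0.59 log units; beyond the scatter), and the comparison with the methyl-bearing analogue gives an at least 2.3-fold higher number from compound 2 to compound 4 (0.36 log units; beyond the scatter), so both steps can be read only as lower bounds on the change. The exchange on the ring in a 1.7-fold higher number from compound 1 to compound 2 (0.23 log units; within the scatter) had left the number within the scatter, whereas 4-methylphenyl, which has no methoxy, moves it beyond the scatter from both 3-fluoro-4-methoxyphenyl and 4-methoxy-3-methylphenyl, so this position is not indifferent to every change in the benzyl group.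

The compounds shown leave open how far past the limit compound 4 lies, and whether the shift follows the loss of the methoxy itself, since each step changes more than one feature of the ring at once. Also open, going by these compounds, is whether a plain 4-methoxyphenyl or a 4-aminophenyl on the same saturated chain carbon would stay with compounds 1 and 2 or move with compound 4.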